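This account rests on a few compounds, and the source may have more. Where it says the series, first, only, none or still open, it means among the compounds named here.

Compound 1, `Cc1nc(N)sc1CCCN/C(N)=N/C(=O)NC(c1ccccc1)C(C)C`, reaches 1.04 in a functional assay on Right cardiac atrium for agonist activity at histamine H2 receptor (Cavia porcellus), with a stated time of 30 min, in the presence of a further agent that is not named here; a higher number here means a larger maximal response, a lower number a smaller maximal response. Compound 2, `Cc1nc(N)sc1CCCN/C(N)=N/C(=O)NC(C)c1ccccc1F`, reaches 0.93 in this assay, which is the lower of the two numbers shown; the gap to compound 1 lies beyond the usual scatter of such measurements, so compound 2 is the weaker of the pair as far as the maximal response goes, though both numbers sit close to the reference agonist's own response.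

Compound 3, `Cc1nc(N)sc1CCCN/C(N)=N/C(=O)NC(C)c1cccs1`, is the next member of the series and has not yet been measured in this assay. It differs from compound 2 in one place: thiophen-2-yl in place of 2-fluorophenyl on a saturated chain carbon bound to an amide-type nitrogen and a saturated chain carbon. Within the data shown here, no measured pair in the set shows what this particular exchange does, so the expectation rests on the two values alone. Both compound 1 and compound 2 behave as near-full agonists, and the change keeps an aromatic ring on the same saturated chain carbon, so the step from compound 2 is expected to be small, if any, and no larger than the scatter, a number 0.020 higher from compound 2 to compound 3 (within the scatter). Compound 3 is therefore estimated to reach 0.95 in this assay, with a range from 0.82 to 1.06.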

Compound 3, intrinsic activity: the largest response reached, as a fraction of the reference agonist's: 0.88
Compound 3: middle estimate off by 0.070, on the high side; low and high end bracket the measured number.
By their numbers in this assay, from the lowest: compounds 3 and 2 (each within the scatter of the next); then compound 1.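

In this assay, placing thiophen-2-yl in place of 2-fluorophenyl on a saturated chain carbon bound to an amide-type nitrogen and a saturated chain carbon gives a number 0.050 lower from compound 2 to compound 3 (within the scatter), so this exchange does not separate the two aromatic rings by their maximal response. The result therefore shows that a five-membered aromatic ring with a sulfur atom and a six-membered carbon ring bearing fluorine can stand at this position with no difference beyond the scatter, although ring size, hetero atom and fluorine all change in the same step and cannot be told apart here. No independent measurement is available that bears on this result.

What the compounds leave open is whether the aromatic character of this group matters at all, since a saturated ring such as cyclohexyl, an unsubstituted phenyl ring or a furan-2-yl ring at the same place would each test a separate part of the exchange. Compound 1 differs from compound 2 and compound 3 in more than one place, so the isopropyl group it carries on that carbon cannot yet be compared with these rings through a single change.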